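The source may report more compounds than this note shows. Statements on the series, on what has been measured and on what is new or still open speak of the compounds shown alone.

Measured so far in a functional assay on HepG2 cells (Homo sapiens) for cytotoxicity, read by MTT assay (on this read-out higher numbers stand for weaker inhibition and lower numbers for stronger inhibition), on the shared core:

- compound 1 `C=C1C(=O)[C@]23C[C@@]1(O)CC[C@H]2[C@@]12C=CC(=O)[C@](C)(C(=O)O1)[C@H]2[C@@H]3C(=O)OCc1ccccc1` gives 20500 nM
- compound 2 `C=C1C(=O)[C@]23C[C@@]1(OCC)CC[C@H]2[C@@]12C=CC(=O)[C@](C)(C(=O)O1)[C@H]2[C@@H]3C(=O)OC` gives 120000 nM

Compound 2 has the higher of the two numbers, so it is the weaker inhibitor of the pair, and the gap lies beyond the scatter. The next compound to be read is compound 3 `C=C1C(=O)[C@]23C[C@@]1(OCC)CC[C@H]2[C@@]12C=CC(=O)[C@](C)(C(=O)O1)[C@H]2[C@@H]3C(=O)OCc1ccccc1` and the change from compound 2 is phenyl in place of hydrogen on a saturated chain carbon bound to an oxygen next to a carbonyl group with phenyl in place of hydrogen on a saturated chain carbon bound to an oxygen next to a carbonyl group. Cut one bond further out, this reads as methoxycarbonyl to benzyloxycarbonyl.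

Among the compounds with values here, no measured pair isolates this change. Compound 1 carries the same benzyloxycarbonyl group and gives 20500 nM but it also differs from compound 3 elsewhere on the core, so it is only an indirect guide. The estimated step is a 4.3-fold lower number from compound 2 to compound 3 (0.63 log units; beyond the scatter) and it is expected to run toward a lower number, meaning stronger inhibition, beyond the scatter. The expected value for compound 3 is 28000 nM with 10000 nM to 80000 nM as its estimated range.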

Compound 3, half-maximal inhibitory concentration: 29600 nM
Beside the measured number, compound 3's estimate is 1.1-fold (0.02 log units) below it; the measured number falls inside the stated range.
By their numbers in this assay, from the lowest: compounds 1 and 3 (each within the scatter of the next); then compound 2.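

Working notes: in this assay, with the ethyl group on the oxygen held constant, methoxycarbonyl to benzyloxycarbonyl gives a 4.1-fold lower number from compound 2 to compound 3 (0.61 log units; beyond the scatter) and so isolates a step on the ester group, in the direction of stronger inhibition. With benzyloxycarbonyl held constant, ethyl in place of hydrogen on an oxygen on a saturated carbon gives a 1.4-fold higher number from compound 1 to compound 3 (0.16 log units; within the scatter) and so leaves that oxygen without a readable effect in this setting; of these two single changes, only the ester change lies beyond the scatter. The compounds shown carry no measurement that explains the size of either step.

Still open, as far as these compounds go, is whether the phenyl ring itself is needed, since a butyl ester or a benzyl ester carrying a chlorine or methoxy group on the ring would separate the ring from simple chain length, and a free carboxylic acid at this place would test whether an ester is needed at all. Also open, from the compounds shown here alone, is whether ethyl on the oxygen stays without a readable effect when methoxycarbonyl replaces benzyloxycarbonyl, which needs the hydroxy methyl ester on the shared core.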